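A few compounds are considered here, and "the series" means these few. Any claim that something is new, unique, unknown or untested is made for them only; others in the source may bear on it.

Compound 1 `CCN1CCN(c2cc(C)c3cc(NC(=O)c4ccc(OC)cc4)ccc3n2)CC1`: 9000 nM
Compound 2 `CCN1CCN(c2cc(C)c3cc(NC(=O)c4ccc5ccccc5n4)ccc3n2)CC1`: 3760 nM
Compound 3 `CCN1CCN(c2cc(C)c3cc(NC(=O)c4ccc(F)cc4)ccc3n2)CC1`: 19800 nM

Of the compounds shown here, three have been measured in a functional assay on SK-BR-3 cells (Homo sapiens) for antiproliferative activity, read by MTT assay, with a stated time of 72 h; on this read-out lower numbers stand for stronger inhibition and higher numbers for weaker inhibition. They share one core and differ only in the group attached to the carbonyl carbon of the amide. Compound 3 carries the highest number of the three, meaning the weakest inhibition: its nearest neighbour is compound 1, reached by a 2.2-fold higher number from compound 1 to compound 3 (0.34 log units; beyond the scatter), and its furthest is compound 2, reached by a 5.3-fold higher number from compound 2 to compound 3 (0.72 log units; beyond the scatter). Both of these steps go beyond the usual scatter, yet both remain modest.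

Compound 4 `CCN1CCN(c2cc(C)c3cc(NC(=O)c4ccccc4)ccc3n2)CC1` has not yet been measured. It differs from compound 3 by hydrogen in place of fluoro on an aromatic carbon. Going by the values given here, no measured step removes a group in favour of hydrogen, so the closest guide is a 2.2-fold higher number from compound 1 to compound 3 (0.34 log units; beyond the scatter), where a fluoro replaced a methoxy at the same place and the number rose modestly. Taking the fluoro away again is therefore expected to move the number only a little, most likely downward, and possibly not beyond the scatter. The step is estimated at a 1.4-fold lower number from compound 3 to compound 4 (0.15 log units; within the scatter). For compound 4 the expected value in this assay is 14000 nM, with a range from 6500 nM to 32000 nM.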

Compound 4, half-maximal inhibitory concentration: 18400 nM
The estimate for compound 4 lay 1.3-fold (0.12 log units) below the measured number; the measured number falls inside the stated range.
By their numbers in this assay, from the lowest: compound 2; then compound 1; then compounds 4 and 3 (each within the scatter of the next).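

In this assay, taking the fluoro away from its place para to a large group gives a 1.1-fold lower number from compound 3 to compound 4 (0.03 log units; within the scatter), so fluoro and hydrogen cannot be told apart at this position. Methoxy at the same place does stand apart from hydrogen, with a 2.0-fold higher number from compound 1 to compound 4 (0.31 log units; beyond the scatter), a modest step beyond the scatter; the earlier difference between methoxy and fluoro therefore looks like something particular to the methoxy compound rather than a penalty for adding fluoro. Exchanging the whole ring matters more than either small group here, as replacing quinolin-2-yl with plain phenyl gives a 4.9-fold higher number from compound 2 to compound 4 (0.69 log units; beyond the scatter), but nothing available explains why any of these groups gives the number it does.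

As far as these compounds go, with only methoxy, fluoro and hydrogen at this position, it remains open whether another oxygen-linked group, such as hydroxyl or ethoxy, would track methoxy, or whether an amine or a carboxylic acid there would give a different number. From the compounds shown here alone, it is also open whether a methoxy group placed on the quinolin-2-yl ring would change the number for compound 2.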